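The source may hold more compounds than are shown below. What is called first, only, known or untested is meant among the compounds shown, and "the series" means these compounds.

Measured compounds in a functional assay on KB 3-1 cells (Homo sapiens) for cytotoxicity, read by MTT assay, with a stated time of 68 h; a higher number here means a weaker inhibitor, a lower number a stronger inhibitor:
compound 1 `CCOc1cccc(-c2cc(NC(=O)C(Cl)Cl)cc(-c3cccc(OCC)c3)c2)c1` — 14800 nM
compound 2 `O=C(Nc1cccc(-c2cccc(Cl)c2)c1)C(Cl)Cl` — > 50000 nM; this is a limit of the assay, not a number.
compound 3 `CC(C)Oc1ccc(-c2cc(NC(=O)C(Cl)Cl)cc(-c3ccc(OC(C)C)cc3)c2)cc1` — 8850 nM

Compound 2 stands at the limit of > 50000 nM in this assay, at which 1 of the 3 values shown sits, the weakest reading the series allows; no number is known for it, only that it lies at the limit. Compound 1 and compound 3 give numbers, both weak. Among the compounds with values here, no pair of measured compounds differs in one place, so no measured step exists to lean on.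

Compound 4 `Cc1cccc(-c2cccc(NC(=O)C(Cl)Cl)c2)c1` differs from compound 2 by methyl in place of chloro on an aromatic carbon. With compound 2 itself only a limit, the step of a number no higher from compound 2 to compound 4 (the limit leaves the size open) is expected to be small, with no direction beyond the scatter. Compound 4 is estimated at 50000 nM, in the range 20000 nM to 150000 nM, and a further limit reading is quite likely.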

Compound 4, half-maximal inhibitory concentration: > 50000 nM
Compound 4: a limit, no number; the forecaster's own chance of this, stated with the estimate: 65%; the middle value lies on the limit itself.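

Compound 2 and compound 4 are both limits and not numbers, so no step can be read between them, because: the limit of > 50000 nM in this assay, at which 2 of the 4 values shown sit.
The reading in this assay leaves open whether methyl in place of chloro on an aromatic carbon changes potency at all.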